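The source may hold more compounds than are shown below. What is called first, only, known or untested is meant among the compounds shown, and "the series" means these compounds.

Measured compounds and their values in an assay on FRT cells for positive allosteric modulation of Cystic fibrosis transmembrane conductance regulator variant N1303K (Homo sapiens), in the presence of a further agent that is not named here; a higher number here means that more compound is needed for the effect, a lower number that less compound is needed:

compound 1, `COc1ccc2[nH]c3c(c2c1)CCNC31CCN(Cc2ccc(F)cc2F)CC1`: 2000 nM
compound 2, `COc1ccc2[nH]c3c(c2c1)CCNC31CCN(Cc2cc(F)cc(F)c2)CC1`: 11100 nM
compound 3, `COc1ccc2[nH]c3c(c2c1)CCNC31CCN(Cc2cc(F)c(F)cc2F)CC1`: 600 nM

The three measured compounds share one core and differ only in the fluorine pattern on the benzyl group. Compound 1 stands second highest of the three numbers in this assay . Its nearest neighbour is compound 3, reached by a 3.3-fold lower number from compound 1 to compound 3 (0.52 log units; beyond the scatter), and its furthest is compound 2, reached by a 5.6-fold higher number from compound 1 to compound 2 (0.74 log units; beyond the scatter). Between those two, a 19-fold lower number from compound 2 to compound 3 (1.27 log units; beyond the scatter) is the largest step in the set.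

Compound 4, `Fc1ccc(CN2CCC3(CC2)NCCc2c3[nH]c3ccc(Cl)cc23)c(F)c1`, keeps the 2,4-difluorophenyl benzyl group of compound 1 and changes the core instead: chloro in place of methoxy on an aromatic carbon, on an aromatic carbon of a six-membered aromatic ring of carbon only, part of a fused or bridged system of four rings. Among the measured compounds shown here, none of the measured steps touches that ring; all of them concern the benzyl fluorines, so no step gives a direct precedent for this change. With nothing in the set pointing either way, the expectation for this assay is a step not beyond the scatter from compound 1, that is no change at the digits printed from compound 1 to compound 4 (within the scatter). Compound 4 is therefore expected at 2000 nM, within a range from 600 nM to 7000 nM, the width reflecting that the change sits in an untested part of the molecule.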

Compound 4, half-maximal effective concentration: 2500 nM
For compound 4 the middle estimate is 1.3-fold (0.10 log units) below the measured one; low and high end bracket the measured number.
By their numbers in this assay, from the lowest: compound 3; then compounds 1 and 4 (each within the scatter of the next); then compound 2.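

In this assay, chloro in place of methoxy on the six-membered aromatic ring of the core gives a 1.3-fold higher number from compound 1 to compound 4 (0.10 log units; within the scatter), the first reading from this part of the molecule. With the 2,4-difluorophenyl benzyl group held constant, the two groups cannot be told apart at this position, although the methoxy group that leaves carries a hydrogen-bond acceptor and the chloro that enters carries none. All the earlier steps, which concern the benzyl fluorines, lie beyond the scatter, whereas this single change on the core does not, and nothing measured here bears on the reason for this result.

This one pair cannot show whether chloro and methoxy would also read alike with another benzyl group, such as the 2,4,5-trifluorophenyl group of compound 3 or the 3,5-difluorophenyl group of compound 2. It also leaves open how other groups at the same position would read, for example a bare hydrogen, a fluoro, a nitrile, an amine or a carboxylic acid, or a longer alkoxy chain such as ethoxy.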